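From methoxy to (4-methylphenyl)amino on a carbonyl carbon

This account rests on a few compounds, and the source may have more. Where it says the series, first, only, none or still open, it means among the compounds named here.

Measured in a functional assay on HeLa cells (Homo sapiens) for cytotoxicity, read by MTT assay, with a stated time of 48 h; on this read-out higher numbers stand for weaker inhibition and lower numbers for stronger inhibition:
compound 1 `C=C/C(C)=C\CC/C(C)=C/c1cc(C(=O)O)co1`: 81000 nM
compound 2 `C=C/C(C)=C\CC/C(C)=C/c1cc(C(=O)OC)co1`: 59400 nM
compound 3 `C=C/C(C)=C/CC/C(C)=C/c1cc(C(=O)OC)co1`: 35500 nM

In this assay compound 2 gives 59400 nM, and it cannot be separated from either of the other two compounds. This is shown by a 1.4-fold lower number from compound 1 to compound 2 (0.13 log units; within the scatter) and by a 1.7-fold lower number from compound 2 to compound 3 (0.22 log units; within the scatter).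

Compound 4 `C=C/C(C)=C\CC/C(C)=C/c1cc(C(=O)Nc2ccc(C)cc2)co1` keeps the core of compound 2 but has (4-methylphenyl)amino in place of methoxy on a carbonyl carbon. Among the compounds with values here, only one measured step alters the group on this carbonyl: a 1.4-fold lower number from compound 1 to compound 2 (0.13 log units; within the scatter). It stays within the scatter, but it involves only a small change and gives no direct guide to an entering aromatic ring. The other measured step, a 1.7-fold lower number from compound 2 to compound 3 (0.22 log units; within the scatter), concerns only the configuration of a double bond and has little bearing on this change.

Within the data shown here, no measured step therefore supports a large shift in this assay. A change beyond the scatter is not expected, though a slight lean towards a lower number is allowed for. This estimate means an expected step of a 1.5-fold lower number from compound 2 to compound 4 (0.17 log units; within the scatter). Compound 4 is estimated at 40000 nM, with an expected range from 13000 nM to 100000 nM.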

Compound 4, half-maximal inhibitory concentration: 59500 nM
For compound 4 the middle estimate is 1.5-fold (0.17 log units) below the measured one, within the range that was stated.
By their numbers in this assay, from the lowest: compounds 3, 2, 4 and 1 (each within the scatter of the next, the first and the last beyond it).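

In this assay this carbonyl carbon proves tolerant of a far larger change than the earlier compounds had tested, since they had shown only hydroxy and methoxy there: a 1.0-fold higher number from compound 2 to compound 4 (0.00 log units; within the scatter). The entering (4-methylphenyl)amino group brings a six-membered aromatic ring of carbon only and a hydrogen-bond donor, yet neither addition produces a step that can be told from the scatter, and the same holds against the free acid: a 1.4-fold lower number from compound 1 to compound 4 (0.13 log units; within the scatter). Hydroxy, methoxy and (4-methylphenyl)amino on this carbonyl carbon therefore cannot be separated from one another in this cell read-out, and nothing given here explains why.

The compounds shown leave open whether any other group on this carbonyl carbon, such as dimethylamino, octylamino or a phenylamino ring carrying a nitro group in place of methyl, would give a step beyond the scatter. They also leave open how the (4-methylphenyl)amino group behaves with the double bond drawn as in compound 3, so its effect is known for only one configuration of the chain.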